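Swapping one chloro for hydrogen on compound 1

A few compounds are considered here, and "the series" means these few. Any claim that something is new, unique, unknown or untested is made for them only; others in the source may bear on it.

Measured in an ADME assay on HEK293 cells (Homo sapiens) for cytotoxicity, read by MTT assay, with a stated time of 48 h; a higher number here means a weaker inhibitor, a lower number a stronger inhibitor:
- compound 1 `Cc1nc(-c2ccc(Cl)cc2)sc1C(=O)CSc1nc(-c2ccc(Cl)c(Cl)c2)c(C#N)c(=O)[nH]1`: 46900 nM
- compound 2 `Cc1nc(-c2ccccc2)sc1C(=O)CSc1nc(-c2ccc(Cl)c(Cl)c2)c(C#N)c(=O)[nH]1`: 85100 nM
- compound 3 `COc1ccc(-c2nc(C)c(C(=O)CSc3nc(-c4ccc(Cl)c(Cl)c4)c(C#N)c(=O)[nH]3)s2)cc1`: 45600 nM

Compound 1 sits among these three values, and its steps to the other two stay within the scatter. Compound 4 `Cc1nc(-c2ccc(Cl)cc2)sc1C(=O)CSc1nc(-c2ccc(Cl)cc2)c(C#N)c(=O)[nH]1` differs from it in one place: hydrogen in place of chloro on an aromatic carbon. This is hydrogen in place of chloro on an aromatic carbon, turning 3,4-dichlorophenyl into 4-chlorophenyl. Among the compounds with values here, no measured step touches that group. The closest guide is the same kind of swap elsewhere in the molecule, a 1.8-fold higher number from compound 1 to compound 2 (0.26 log units; within the scatter). The swap to methoxy at that same spot, a 1.0-fold lower number from compound 1 to compound 3 (0.01 log units; within the scatter), is small as well. No change beyond the scatter is therefore expected in this assay. The estimated change is a 1.2-fold higher number from compound 1 to compound 4 (0.07 log units; within the scatter). Compound 4 is expected at 55000 nM, with a range of 25000 nM to 110000 nM.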

Compound 4, half-maximal inhibitory concentration: 75100 nM
Beside the measured number, compound 4's estimate is 1.4-fold (0.14 log units) below it; the range from low to high includes it.
By their numbers in this assay, from the lowest: compounds 3, 1, 4 and 2 (each within the scatter of the next).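

In this assay, within the data shown here, turning 3,4-dichlorophenyl into 4-chlorophenyl gives a 1.6-fold higher number from compound 1 to compound 4 (0.20 log units; within the scatter) and is the first direct reading of this group. Among these compounds, removing this chloro therefore leaves the number within the scatter, as does the same kind of swap elsewhere in the molecule, a 1.8-fold higher number from compound 1 to compound 2 (0.26 log units; within the scatter) from the earlier compounds. No measurement at hand speaks to what lies behind these numbers. Still open, going by these compounds, is whether an amine or a carboxylic acid in place of this chloro would move the number beyond the scatter. The compounds shown also leave open what happens when the remaining chloro on this group is replaced.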